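The source may hold more compounds than are shown below. What is called first, only, known or untested is meant among the compounds shown, and "the series" means these compounds.

Working notes on the series. In a functional assay on isolated protein for agonist activity at Glucose-dependent insulinotropic receptor (Homo sapiens), read by HTRF and cAMP accumulation (on this read-out higher numbers stand for larger maximal responses and lower numbers for smaller maximal responses), compound 1 `CS(=O)(=O)c1cnc(O[C@H]2CC[C@H](OC3CCN(CC4(C(F)(F)F)CCC4)CC3)CC2)cn1` gives 96% and compound 2 `CS(=O)(=O)c1cnc(O[C@H]2CC[C@H](OC3CCN(CC4(C(F)(F)F)CCCC4)CC3)CC2)cn1` gives 37%. Within the data shown here, compound 2 holds the lower of the two numbers measured so far; its nearest neighbour is compound 1, which stands higher by the step of a number 59 percentage points lower from compound 1 to compound 2 (beyond the scatter). That step, which swaps the smaller ring for the larger one on the saturated chain carbon bound to the amine nitrogen in the ring, shows that this position moves the maximal response strongly.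

Compound 3 `CC(F)Cc1nc(CN2CCC(O[C@H]3CC[C@H](Oc4cnc(S(C)(=O)=O)cn4)CC3)CC2)no1` is not yet measured. It differs from compound 2 at the same position: a group of 9 heavy atoms (5 carbon, 2 nitrogen, 1 oxygen, 1 fluorine; one five-membered aromatic ring with 3 hetero atoms) in place of a group of 9 heavy atoms (6 carbon, 3 fluorine; one five-membered non-aromatic ring of carbon only), on a saturated chain carbon bound to an amine nitrogen in a ring. Among the measured compounds shown here, only the step from compound 1 to compound 2 bears on this position, and it was large, but it concerned a change in ring size of a saturated ring, not the entry of an aromatic ring with three hetero atoms. The direction for compound 3 is therefore open; a sizeable movement in either direction is plausible, with a return toward the number of compound 1 as likely as a further loss.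

Compound 3 is expected to give about 65% in this assay, the range being 25% to 105%, which would mean an estimated step of a number 28 percentage points higher from compound 2 to compound 3 (beyond the scatter).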

Compound 3, largest response reached (Emax), in percent of the reference or control that the assay uses: 97%
For compound 3 the middle estimate is 32 percentage points below the measured one; low and high end bracket the measured number.
By their numbers in this assay, from the lowest: compound 2; then compounds 1 and 3 (each within the scatter of the next).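

In this assay, the change on the saturated chain carbon bound to an amine nitrogen in a ring gives a number 60 percentage points higher from compound 2 to compound 3 (beyond the scatter) and so recovers the loss seen with compound 2, which shows that the shared core can still give a large maximal response when this group is replaced. Comparing the two groups with a high response, 5-(2-fluoropropyl)-1,2,4-oxadiazol-3-yl in place of 1-(trifluoromethyl)cyclobutyl gives a number 1 percentage points higher from compound 1 to compound 3 (within the scatter), so a five-membered aromatic ring with 3 hetero atoms and a four-membered ring of carbon only read alike here. A large maximal response at this position is therefore not tied to a carbon ring or to a trifluoromethyl group, and among these three compounds only compound 2 stands apart. Nothing measured on these compounds accounts for either step.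

As far as these compounds go, it remains open whether the response depends on the fluorine of the 2-fluoropropyl chain or on the oxadiazole ring itself, which a plain propyl chain on the same ring or a phenyl ring in its place would help to separate. Also open, from the compounds shown here alone, is whether the loss follows ring size alone, as a 1-(trifluoromethyl)cyclohexyl group would indicate.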